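The compounds below may be only part of what the source reports. "The series", "measured", "known", "first", "only" and "open" are said of these compounds alone.

Measured so far in an assay on microsomes from liver for inhibition of 3-hydroxy-3-methylglutaryl-coenzyme A reductase (Rattus norvegicus); on this read-out lower numbers stand for stronger inhibition and higher numbers for weaker inhibition:
- compound 1 `CCN(Cc1ccccc1)C(=O)c1nn(-c2ccc(F)cc2)c(OC[C@@H](O)C[C@@H](O)CC(=O)O)c1C(C)C`: 14 nM
- compound 2 `CC(C)c1c(C(=O)N(C)Cc2ccccc2)nn(-c2ccc(F)cc2)c1OC[C@@H](O)C[C@@H](O)CC(=O)O`: 5.2 nM
- compound 3 `CC(C)c1c(C(=O)NCC2CCCCC2)nn(-c2ccc(F)cc2)c1OC[C@@H](O)C[C@@H](O)CC(=O)O`: 17 nM

Compound 3 gives the highest number of the three; the step within the scatter is a 1.2-fold higher number from compound 1 to compound 3 (0.08 log units; within the scatter), the step beyond it is a 3.3-fold higher number from compound 2 to compound 3 (0.51 log units; beyond the scatter).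

Compound 4 `CC(C)c1c(C(=O)NCc2cccc(F)c2F)nn(-c2ccc(F)cc2)c1OC[C@@H](O)C[C@@H](O)CC(=O)O` differs from compound 3 by 2,3-difluorophenyl in place of cyclohexyl on a saturated chain carbon bound to an amide-type nitrogen. Going by the values given here, the steps that bear on this are a 1.2-fold higher number from compound 1 to compound 3 (0.08 log units; within the scatter) and a 3.3-fold higher number from compound 2 to compound 3 (0.51 log units; beyond the scatter), where an aromatic ring on that chain carbon gave equal or lower numbers than the saturated ring, although the amide-type nitrogen there also carried an alkyl group. Among the compounds with values here, the two fluorine atoms have no counterpart among the measured compounds. Going back to an aromatic ring, a modest lowering is expected, a 1.7-fold lower number from compound 3 to compound 4 (0.23 log units; within the scatter); compound 4 is estimated at 10 nM, range 4 nM to 25 nM.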

Compound 4, half-maximal inhibitory concentration: 2 nM
Compound 4: the middle estimate sits 5.0-fold (0.70 log units) above what was measured, and the stated range ends above it.
By their numbers in this assay, from the lowest: compound 4; then compound 2; then compounds 1 and 3 (each within the scatter of the next).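

In this assay, 2,3-difluorophenyl in place of cyclohexyl on a saturated chain carbon bound to an amide-type nitrogen gives an 8.5-fold lower number from compound 3 to compound 4 (0.93 log units; beyond the scatter), a larger step than any earlier one in the series. With the amide hydrogen kept, the 2,3-difluorobenzyl group also gives a 2.6-fold lower number from compound 2 to compound 4 (0.41 log units; beyond the scatter) and a 7.0-fold lower number from compound 1 to compound 4 (0.85 log units; beyond the scatter), so an alkyl group on that nitrogen is not needed for a low number. Nothing measured here gives a reason for these steps.

Going by these compounds, how much of the change belongs to the aromatic ring and how much to the two fluorine atoms stays open. (Benzyl)amino or (2-fluorobenzyl)amino on the carbonyl carbon would separate the two.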